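The source may hold more compounds than are shown below. What is called first, only, known or untested is meant among the compounds shown, and "the series" means these compounds.

Within the data shown here, compound 1 `Nc1cc(N)c2nc(-c3ccccc3)c(Oc3ccc(Cl)c(Cl)c3)nc2c1` stands at the second highest of the three numbers known: in a functional assay on MDA-MB-231 cells (Homo sapiens) for inhibition, read by sulforhodamine B assay, with a stated time of 48 h (on this read-out higher numbers stand for weaker inhibition of growth and lower numbers for stronger inhibition of growth), compound 1 gives 26300 nM. Compound 3 `CCOC(=O)[C@H](CCC(=O)O)NC(=O)c1ccc(Sc2nc3cc(N)cc(N)c3nc2-c2ccccc2)cc1` gives 35500 nM in this assay, a number within the scatter of compound 1, while compound 2 `Nc1cc(N)c2nc(-c3ccccc3)c(NCc3ccc(Cl)c(Cl)c3)nc2c1` gives 4470 nM, a lower number beyond the scatter. Compound 4 `Nc1cc(N)c2nc(-c3ccccc3)c(Sc3ccc(F)cc3)nc2c1` differs from compound 1 by (4-fluorophenyl)sulfanyl in place of 3,4-dichlorophenoxy on an aromatic carbon. Among the measured compounds shown here, no step between measured compounds matches this change, so little can be leaned on, and compound 3 with its own sulfanyl link is not a close parallel. Compound 4 is expected to show no step beyond the scatter, a 1.3-fold lower number from compound 1 to compound 4 (0.12 log units; within the scatter). Compound 4 is estimated at 20000 nM, with a range from 6000 nM to 60000 nM.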

Compound 4, concentration for total growth inhibition: 38000 nM
Beside the measured number, compound 4's estimate is 1.9-fold (0.28 log units) below it; measured number inside the range.
By their numbers in this assay, from the lowest: compound 2; then compounds 1, 3 and 4 (each within the scatter of the next).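

In this assay the swap of 3,4-dichlorophenoxy for (4-fluorophenyl)sulfanyl on the aromatic carbon next to the ring nitrogen gives a 1.4-fold higher number from compound 1 to compound 4 (0.16 log units; within the scatter) and so leaves the number in place. Among these compounds, this is the first step read at this position, and it shows that changing the link atom and the halogens together moves nothing beyond the scatter. No measurement offered here explains this result. Going by these compounds, whether the link atom and the halogens each matter alone stays open, since they changed together. A 4-fluorophenoxy group or a morpholine at this position could give a different number.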